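The source may report more compounds than this note shows. Statements on the series, on what has been measured and on what is new or still open speak of the compounds shown alone.

Measured compounds in a functional assay on HepG2 cells (Homo sapiens) for inhibition, read by MTT assay, with a stated time of 72 h; a higher number here means a weaker inhibitor, a lower number a stronger inhibitor:
compound 1 `O=C(Nc1cccc(OCc2cn(-c3ccccc3)nn2)c1)Nc1ccc(Cl)c(C(F)(F)F)c1`: 1780 nM
compound 2 `N#Cc1ccccc1-n1cc(COc2cccc(NC(=O)Nc3ccc(Cl)c(C(F)(F)F)c3)c2)nn1`: 1970 nM
compound 3 `CCc1ccc(-n2cc(COc3cccc(NC(=O)Nc4ccc(Cl)c(C(F)(F)F)c4)c3)nn2)cc1`: 1950 nM

The three values lie within the scatter of one another, so compound 3 stands level with compound 1 and compound 2: the steps of a 1.1-fold higher number from compound 1 to compound 3 (0.04 log units; within the scatter) and a 1.0-fold lower number from compound 2 to compound 3 (0.00 log units; within the scatter) are both within the scatter. Compound 4 `O=C(Nc1cccc(OCc2cn(-c3ccc(F)cc3)nn2)c1)Nc1ccc(Cl)c(C(F)(F)F)c1` has not been measured. It differs from compound 3 by fluoro in place of ethyl on an aromatic carbon, a substituent change on the same ring that was varied in the measured steps. Those steps, a 1.1-fold higher number from compound 1 to compound 3 (0.04 log units; within the scatter) and a 1.1-fold higher number from compound 1 to compound 2 (0.04 log units; within the scatter), were both small, so a change at this place is expected to move the number by no more than the scatter. For compound 4 the expected step is a 1.0-fold lower number from compound 3 to compound 4 (0.01 log units; within the scatter), giving an estimate of 1900 nM with a range from 1000 nM to 3600 nM.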

Compound 4, half-maximal inhibitory concentration: 1350 nM
Compound 4: the middle estimate sits 1.4-fold (0.15 log units) above what was measured, within the range that was stated.
By their numbers in this assay, from the lowest: compounds 4, 1, 3 and 2 (each within the scatter of the next).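

In this assay, fluoro on this aromatic carbon gives no step beyond the scatter, whether set against ethyl, a 1.4-fold lower number from compound 3 to compound 4 (0.16 log units; within the scatter), against hydrogen, a 1.3-fold lower number from compound 1 to compound 4 (0.12 log units; within the scatter), or with 4-fluorophenyl in place of 2-cyanophenyl, a 1.5-fold lower number from compound 2 to compound 4 (0.16 log units; within the scatter). Hydrogen, ethyl and fluoro at this carbon therefore all stand level, and the flatness seen earlier now extends to a halogen. Nothing available accounts for these small steps. As far as these compounds go, whether an amine, a carboxylic acid or a longer chain at this carbon would give a step beyond the scatter stays open. So does the effect of changes elsewhere on the shared core.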